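The compounds below may be only part of what the source reports. "The series", "measured", "known", "first", "only" and "open" are said of these compounds alone.

Growth inhibition in a functional assay on SW-620 cells (Homo sapiens); on this read-out higher numbers stand for weaker inhibition of growth and lower numbers for stronger inhibition of growth:
Compound 1 `O=S(=O)(/C=C/c1ccc(F)cc1F)Cc1ccc(Nc2ncnc3ccccc23)cc1`: 86000 nM
Compound 2 `O=S(=O)(/C=C/c1ccc(C(F)(F)F)cc1F)Cc1ccc(Nc2ncnc3ccc(Br)cc23)cc1`: 55000 nM
Compound 3 `O=S(=O)(/C=C/c1ccc(C(F)(F)F)cc1F)Cc1ccc(Nc2ncnc3cc(Cl)ccc23)cc1`: > 100000 nM

Compound 3 stands at the limit of > 100000 nM in this assay, at which 1 of the 3 values shown sits. For compound 3 the entry > 100000 nM is a limit of the assay and not a number.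

Compound 4 `O=S(=O)(/C=C/c1ccc(F)cc1F)Cc1ccc(Nc2ncnc3cc(Cl)ccc23)cc1` differs from compound 3 in one place: 2-fluoro-4-(trifluoromethyl)phenyl becomes 2,4-difluorophenyl, with fluoro in place of trifluoromethyl on an aromatic carbon. Within the data shown here, no measured step makes this exact change. The only one available, an at least 1.8-fold higher number from compound 2 to compound 3 (0.25 log units; that floor lies within the scatter), alters the core and leaves this group untouched.

Some indirect help comes from two other compounds. Like compound 4, compound 1 carries the 2,4-difluorophenyl group and gives 86000 nM. Compound 2 carries the trifluoromethyl group and gives 55000 nM. These two values lie within the scatter of each other, although the two compounds also differ in their cores.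

On this evidence, no step beyond the scatter is expected in this assay, so any direction is tentative. The expected change is small, an at least 1.1-fold lower number from compound 3 to compound 4 (0.04 log units; that floor lies within the scatter), and compound 4 may well reach the limit too. Compound 4 is estimated at 90000 nM, with an expected range from 45000 nM to 180000 nM.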

Compound 4, concentration for 50% growth inhibition: > 100000 nM
Compound 4 was reported as a limit; the forecaster's own chance of this, stated with the estimate: 45%; at least 1.1-fold (0.04 log units) between middle value and limit.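

In this assay, the change from 2-fluoro-4-(trifluoromethyl)phenyl to 2,4-difluorophenyl cannot be read, because compound 3 and compound 4 rest on the same limit and neither gives an actual number: the limit of > 100000 nM in this assay, at which 2 of the 4 values shown sit. What is new is that the core of compound 3 reaches this limit with either group, so reaching it does not depend on trifluoromethyl being present at this place. Among these compounds, the one readable step, chloro in place of hydrogen on an aromatic carbon of the core, is an at least 1.1-fold higher number from compound 1 to compound 4 (0.06 log units; that floor lies within the scatter); since only a floor is known, the true size of this step may be larger, but nothing shows a change beyond the usual scatter.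

The compounds shown leave open whether trifluoromethyl and fluoro differ at all on a core that gives numbers rather than a limit. They also leave open whether another group at this place, such as an amine or a carboxylic acid, would bring the core of compound 4 into the range where growth inhibition can be measured.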